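Swapping Fluoro for Trifluoromethyl in a Receptor Binder

The source may hold more compounds than are shown below. What is called first, only, known or untested is meant among the compounds shown, and "the series" means these compounds.

Of the compounds shown here, two have numbers so far. Compound 1, `C=Cc1ccccc1C(Nc1ccc(C)cc1Cl)C(=O)CCc1ccncc1`, gives in an assay on isolated protein for binding affinity to corticotropin-releasing factor receptor 1 (Homo sapiens) (on this read-out lower numbers stand for stronger inhibition and higher numbers for weaker inhibition), a value of 752 nM; 752 nM (2 entries). Compound 2, `Cc1ccc(NC(C(=O)CCc2ccncc2)c2ccccc2C)c(F)c1`, gives in this assay a value of 439 nM; this is the only number shown for it, and one further entry for compound 2 carries no single number. Compound 3, `Cc1ccc(NC(C(=O)CCc2ccncc2)c2ccccc2C)c(C(F)(F)F)c1`, has not been measured yet. The change from compound 2 to compound 3 is trifluoromethyl in place of fluoro on an aromatic carbon. Among the compounds with values here, no measured pair shows this single change, so there is nothing direct to lean on; compound 1 differs from compound 2 in two places at once, and their two values can only be set side by side. The step in this assay is expected to be small, an estimated 1.3-fold lower number from compound 2 to compound 3 (0.10 log units; within the scatter). Compound 3 is therefore estimated at 350 nM, with a range from 120 nM to 1000 nM.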

Compound 3, inhibition constant: 641 nM
Estimate against measurement, compound 3: 1.8-fold (0.26 log units) below; measured number inside the range.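

Within the data shown here, this is the first direct pair for this change: with trifluoromethyl in place of fluoro on an aromatic carbon ortho to a large group, the binding read-out shows a 1.5-fold higher number from compound 2 to compound 3 (0.16 log units; within the scatter) and stays within the usual scatter. At this position, a group of 4 heavy atoms can therefore replace one of 1 without a clear shift in the number, and neither compound can be ranked above the other. No measurement at hand gives a reason for this outcome.

From the compounds shown here alone, it remains open how an amine or a methoxy group on this same aromatic carbon would read in this assay. Going by these compounds, it is also open whether the same swap would give a similarly small step on a core carrying other groups elsewhere.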